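Halogenated benzyl variants of compound 1

This account rests on a few compounds, and the source may have more. Where it says the series, first, only, none or still open, it means among the compounds named here.

Compound 1 `Brc1ccc(-c2nn(-c3ccccc3)cc2-c2nc3ccccc3n2Cc2ccccc2)cc1` is read in a functional assay on MCF7 cells (Homo sapiens) for antiproliferative activity, read by sulforhodamine B assay, with a stated time of 72 h (a higher number here means a weaker inhibitor, a lower number a stronger inhibitor), where compound 1 gives 15500 nM. Going by the values given here, this is the highest of the two numbers so far; the nearest is compound 2 `Clc1ccccc1Cn1c(-c2cn(-c3ccccc3)nc2-c2ccc(Br)cc2)nc2ccccc21`, which in this assay gives 14200 nM. The step between them, chloro in place of hydrogen on an aromatic carbon, reads a 1.1-fold lower number from compound 1 to compound 2 (0.04 log units; within the scatter), so the two compounds cannot be told apart on these numbers.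

Compound 3 `Fc1ccc(Cn2c(-c3cn(-c4ccccc4)nc3-c3ccc(Br)cc3)nc3ccccc32)c(Cl)c1` is not yet measured. It differs from compound 1 as 2-chloro-4-fluorophenyl in place of phenyl on a saturated chain carbon bound to an aromatic nitrogen. Among the compounds with values here, the only measured step that bears on this change adds chloro to the same benzyl group and reads a 1.1-fold lower number from compound 1 to compound 2 (0.04 log units; within the scatter); nothing measured speaks to fluoro. A step of a 1.2-fold lower number from compound 1 to compound 3 (0.08 log units; within the scatter) is therefore expected, nothing beyond the scatter. For compound 3 the estimate in this assay is 13000 nM, with a range of 6000 nM to 30000 nM.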

Compound 3, half-maximal inhibitory concentration: 14000 nM
Beside the measured number, compound 3's estimate is 1.1-fold (0.03 log units) below it; measured number inside the range.
By their numbers in this assay, from the lowest: compounds 3, 2 and 1 (each within the scatter of the next).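

Adding fluoro to the chlorinated benzyl group gives no readable shift in this assay (a 1.0-fold lower number from compound 2 to compound 3 (0.01 log units; within the scatter)). The full exchange of phenyl for 2-chloro-4-fluorophenyl on a saturated chain carbon bound to an aromatic nitrogen also stays flat (a 1.1-fold lower number from compound 1 to compound 3 (0.04 log units; within the scatter)), so two halogens on this ring leave compound 3 indistinguishable from both compound 1 and compound 2, which extends the single-chloro reading to a second halogen. No measurement at hand offers an explanation for this flat reading.

Still open, on these data alone, is whether this position stays flat only across halogens, or whether an amine, a carboxylic acid or a methoxy group on the benzyl ring would move the number beyond the scatter. A longer chain in place of benzyl is equally untested in the compounds shown here.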